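A few compounds are considered here, and "the series" means these few. Any claim that something is new, unique, unknown or untested is made for them only; others in the source may bear on it.

Measured compounds:
compound 1, `O=C(O)CCCCCSc1cc(-c2ccccc2)c(-c2ccccc2)nn1`: > 300000 nM
compound 2, `O=C(O)CCCCCCCSc1cc(-c2ccccc2)c(-c2ccccc2)nn1`: > 300000 nM

In an assay on microsomes from liver for inhibition of sterol O-acyltransferase 1 (Rattus norvegicus) (on this read-out higher numbers stand for weaker inhibition and lower numbers for stronger inhibition), compound 1 gives only a limit, > 300000 nM. Compound 2 also gives only a limit in this assay, namely > 300000 nM. The step that the two limits leave unreadable from compound 1 to compound 2 therefore cannot be read, and compound 2 stands at the limit together with compound 1 (the limit of > 300000 nM in this assay, at which 2 of the 2 values shown sit).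

Compound 3, `O=C(O)CCCCCCCCSc1cc(-c2ccccc2)c(-c2ccccc2)nn1`, is not yet measured; it differs from compound 2 by carboxymethyl in place of carboxy on a saturated chain carbon, seven bonds along the chain from a sulfur. For the measured compounds named here, the one measured step, from compound 1 to compound 2, is a change of the same kind but yields no size and no direction, so nothing can be taken from it beyond the fact that both ends sit at the limit.

With both values shown sitting at the limit (the limit of > 300000 nM in this assay, at which 2 of the 2 values shown sit), compound 3 is expected to remain at or around that limit, the estimated step of a number no higher from compound 2 to compound 3 (the limit leaves the size open) meaning nothing beyond the scatter. Compound 3 is estimated at 300000 nM, within 100000 nM to 1000000 nM.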

Compound 3, half-maximal inhibitory concentration: > 300000 nM
Compound 3: no number, only a limit (the forecaster's own chance of this, stated with the estimate: 90%); the middle value lies on the limit itself.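

In this assay no step can be read among compound 1, compound 2 and compound 3, as all three give only a limit: the limit of > 300000 nM in this assay, at which 3 of the 3 values shown sit. The compounds shown leave open whether chain length affects inhibition at all, and how large any such change would be.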